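Replacing nitro with hydrogen: compound 2 to compound 3

The source may hold more compounds than are shown below. What is called first, only, known or untested is meant among the compounds shown, and "the series" means these compounds.

In an ADME assay on RAW264.7 cells (Mus musculus) for cytotoxicity, read by MTT assay, with a stated time of 48 h (on this read-out lower numbers stand for higher toxicity in this test and higher numbers for lower toxicity in this test), compound 1 `COc1ccc(NC(=S)N/N=C\c2ccnc3ccccc23)cc1` gives 101000 nM and compound 2 `O=[N+]([O-])c1ccc(NC(=S)N/N=C\c2ccnc3ccccc23)cc1` gives 82500 nM. Compound 2 therefore stands level with compound 1, as the two numbers lie within the scatter of each other. Compound 3 `S=C(N/N=C\c1ccnc2ccccc12)Nc1ccccc1` follows from compound 2 by hydrogen in place of nitro on an aromatic carbon, para to a large group. For the measured compounds named here, only one measured step bears on this change, a 1.2-fold lower number from compound 1 to compound 2 (0.09 log units; within the scatter), where nitro takes the place of methoxy on an aromatic carbon. That step is small, but it gives no direct reading for hydrogen. No shift beyond the scatter is therefore expected in this assay. The expected change is a 1.2-fold higher number from compound 2 to compound 3 (0.06 log units; within the scatter). For compound 3 the estimated value is 95000 nM, with an expected range of 50000 nM to 180000 nM.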

Compound 3, half-maximal cytotoxic concentration: 118000 nM
Compound 3: middle estimate off by 1.2-fold (0.09 log units), on the low side; the range from low to high includes it.
By their numbers in this assay, from the lowest: compounds 2, 1 and 3 (each within the scatter of the next).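

In this assay, the two steps that bring in hydrogen read a 1.4-fold higher number from compound 2 to compound 3 (0.16 log units; within the scatter) and a 1.2-fold higher number from compound 1 to compound 3 (0.07 log units; within the scatter), both within the scatter. Compound 3 supplies the reference with no substituent at this place, on an aromatic carbon para to a large group, and neither nitro nor methoxy stands apart from hydrogen there in this test. The data at hand give no reason for this lack of separation.

Still open, as far as these compounds go, is whether an amine, a carboxylic acid or a chlorine atom at this place would stand apart from these three compounds in the same test. From the compounds shown here alone, the part played by the shared core also stays open, as only this one place varies among them.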